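Solubility in an aminoquinoline series: swapping the aryl group

The compounds below may be only part of what the source reports. "The series", "measured", "known", "first", "only" and "open" are said of these compounds alone.

Measured compounds:
compound 1 `COc1ccc(Oc2ccc3c(NCCCNCc4cc(F)ccc4OC)ccnc3c2)cc1`: 14500 nM
compound 2 `Fc1ccc(-c2ccc3c(NCCCNCc4ccco4)ccnc3c2)cc1`: 32000 nM
compound 3 `COc1cccc(CNCCCNc2ccnc3cc(-c4ccc(C(F)(F)F)cc4)ccc23)c1O`: 32000 nM

Of the compounds shown here, three built on a shared core have been measured in a physicochemical assay for solubility, with a stated time of 18 h, at pH 7.4; on this read-out lower numbers stand for lower solubility and higher numbers for higher solubility. Compound 3 gives 32000 nM. In this assay compound 2 gives 32000 nM, the same figure at the digits reported, so the two are within the scatter of each other and together sit at the top of the three numbers. The furthest from compound 3 is compound 1, which gives 14500 nM, a lower number that lies beyond the scatter.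

Compound 4 `COc1ccccc1Oc1ccc2c(NCCCNCc3cccc(OC)c3O)ccnc2c1` has not been measured. It differs from compound 3 in one place: 2-methoxyphenoxy in place of 4-(trifluoromethyl)phenyl on an aromatic carbon. For the measured compounds named here, no measured pair in this set shows that exact exchange, so the expectation rests on the spread of the three numbers. Since compound 1 gives 14500 nM and compound 3 gives 32000 nM, the whole set spans a modest range, and compound 4 is expected to fall inside it. The step from compound 3 to compound 4 is estimated as a 1.3-fold lower number from compound 3 to compound 4 (0.12 log units; within the scatter), a small move downward that may not exceed the scatter. Compound 4 is therefore expected to give about 24000 nM, with a likely range from 10000 nM to 50000 nM.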

Compound 4, solubility: 14500 nM
Compound 4: the middle estimate sits 1.7-fold (0.22 log units) above what was measured, within the range that was stated.
By their numbers in this assay, from the lowest: compounds 1 and 4 (each within the scatter of the next); then compounds 2 and 3 (each within the scatter of the next).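

In this assay, the exchange of 4-(trifluoromethyl)phenyl for 2-methoxyphenoxy on this aromatic carbon, with the rest of the molecule unchanged, gives a 2.2-fold lower number from compound 3 to compound 4 (0.34 log units; beyond the scatter). For the compounds shown here, this is the first reading tied to a single place, as the earlier compounds differed from one another in more than one place and no step could be assigned to any one exchange; it shows that the read-out responds to the group at this position, at least for this pair. The entering group counts 9 heavy atoms and 2 hydrogen-bond acceptors against 10 heavy atoms and 0 hydrogen-bond acceptors for the group that leaves, but nothing measured here connects either difference to the step.

The compounds shown leave open which part of the exchange carries the step, the oxygen link to the aryl ring or the substituents on that ring, since no pair separates them. They also leave open how the position would read with a morpholine or a carboxylic acid on the aryl ring, and whether the same exchange would give a similar step on a different side chain.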